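A few compounds are considered here, and "the series" means these few. Any claim that something is new, unique, unknown or untested is made for them only; others in the source may bear on it.

In a physicochemical assay for solubility, in phosphate buffer, at pH 7.4 (a lower number here means a less soluble compound, a higher number a more soluble compound), compound 3 `OC1CN(c2nccnc2OC2CN(c3ccc4ccccc4n3)C2)C1` gives 41000 nM and stands in the middle of the three measured compounds. Compound 1 `OCC1CCN(c2nccnc2Oc2ccc(Nc3nc4ccccc4s3)cc2)CC1` lies lower at 6000 nM and compound 2 `OCC1CCN(c2nccnc2OC2CN(c3cnc4ccccc4n3)C2)CC1` lies higher at 500000 nM with both gaps to compound 3 beyond the scatter. Compound 4 `NC(=O)C1CCN(c2nccnc2OC2CN(c3ccc4ccccc4n3)C2)CC1` differs from compound 3 in one place, with 4-carbamoylpiperidin-1-yl in place of 3-hydroxyazetidin-1-yl on an aromatic carbon. Going by the values given here, no two measured compounds differ in one place only, so the data offer no direct guide to this swap. The expected step of a 1.2-fold higher number from compound 3 to compound 4 (0.09 log units; within the scatter) stays within the scatter, with no firm direction. For compound 4 an estimated 50000 nM is expected, with a likely range from 12000 nM to 200000 nM around it.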

Compound 4, solubility: 14000 nM
For compound 4 the middle estimate is 3.6-fold (0.55 log units) above the measured one, within the range that was stated.
By their numbers in this assay, from the lowest: compound 1; then compound 4; then compound 3; then compound 2.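

Going by these compounds alone, replacing 3-hydroxyazetidin-1-yl with 4-carbamoylpiperidin-1-yl on this aromatic carbon gives a 2.9-fold lower number from compound 3 to compound 4 (0.47 log units; beyond the scatter) in this assay and is the only single change that can be read so far. The group at this position therefore moves the number, even though the hydrogen-bond donor and acceptor counts stay the same and neither group carries a net charge. Nothing measured here explains the step.

This step changes the ring size and the ring's substituent together, so it cannot separate the two. 4-Hydroxypiperidin-1-yl or 3-carbamoylazetidin-1-yl would pull them apart, and an amine on the ring remains an open case.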